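Swapping the Side-Chain Ring on Compound 2

This account rests on a few compounds, and the source may have more. Where it says the series, first, only, none or still open, it means among the compounds named here.

Within the data shown here, in a functional assay on HepG2 cells (Homo sapiens) for antiproliferative activity, read by MTT assay, with a stated time of 48 h (a lower number here means a stronger inhibitor, a higher number a weaker inhibitor), compound 2 `CN1CCN(CCCOc2c(OCc3ccccc3)cc3oc(-c4ccccc4)cc(=O)c3c2O)CC1` gives 2400 nM and holds the lowest of the three numbers measured so far. Compound 3 `COc1cc2oc(-c3ccccc3)cc(=O)c2c(O)c1OCCCN1CCN(C)CC1` gives 15100 nM and compound 1 `CN1CCN(CCCCOc2c(O)cc3oc(-c4ccccc4)cc(=O)c3c2O)CC1` gives 93700 nM as the highest number.

Compound 4 `O=c1cc(-c2ccccc2)oc2cc(OCc3ccccc3)c(OCCCCN3CCCC3)c(O)c12` has not been measured yet. The structural change from compound 2 is (pyrrolidin-1-yl)methyl in place of 4-methylpiperazin-1-yl on a saturated chain carbon, three bonds along the chain from an oxygen on an aromatic ring and it can equally be read as 3-(4-methylpiperazin-1-yl)propyl to 4-(pyrrolidin-1-yl)butyl.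

Among the measured compounds shown here, the one measured single change is a 6.3-fold higher number from compound 2 to compound 3 (0.80 log units; beyond the scatter) when hydrogen replaces phenyl. It is a modest step, but compound 4 keeps the phenyl of compound 2, so that step does not size this swap. For the measured compounds named here, no measured pair isolates the swap, which leaves no basis for predicting a direction. The expectation therefore stays close to compound 2 at 2400 nM with a wide margin.

The expected step is a 1.3-fold higher number from compound 2 to compound 4 (0.10 log units; within the scatter) in this assay and no change beyond the scatter is anticipated. For compound 4 the estimated value is 3000 nM with an expected range from 1000 nM to 10000 nM in this assay overall.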

Compound 4, half-maximal inhibitory concentration: 2000 nM
The estimate for compound 4 lay 1.5-fold (0.18 log units) above the measured number, within the range that was stated.
By their numbers in this assay, from the lowest: compounds 4 and 2 (each within the scatter of the next); then compound 3; then compound 1.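

Among these compounds, the step in this assay is a 1.2-fold lower number from compound 2 to compound 4 (0.08 log units; within the scatter), the first reading at this end of the side chain, since the earlier step concerned the group on the other oxygen. It shows that 3-(4-methylpiperazin-1-yl)propyl can give way to 4-(pyrrolidin-1-yl)butyl, a different ring on a differently named chain, with no change beyond the scatter, so the piperazine ring is not required for this level of activity in this pair. Nothing available explains why the two compounds read alike.

Ring and chain length changed together here, so their separate contributions stay unknown, and they could even offset each other; a 3-(pyrrolidin-1-yl)propyl chain would pull them apart. Also open, as far as these compounds go, is whether an open-chain amine such as diethylamino at the chain end would fit the same picture.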